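This account rests on a few compounds, and the source may have more. Where it says the series, first, only, none or still open, it means among the compounds named here.

Compound 1 `O=C(CCc1cccc2c1B(O)OC2)Nc1nccs1` and compound 2 `O=C(CCc1cccc2c1B(O)OC2)Nc1cccc(Br)c1` are the two measured compounds.

In a functional assay on HCT-116 cells (Homo sapiens) for antiproliferative activity, read by MTT assay, with a stated time of 72 h (a lower number here means a stronger inhibitor, a higher number a weaker inhibitor), compound 1 gives only a limit, > 100000 nM. Compound 1 thus sits at the limit of > 100000 nM in this assay, at which 1 of the 2 values shown sits. In this assay compound 2 gives 1400 nM, the only number shown. Going by the values given here, the single measured step, an at least 71-fold lower number from compound 1 to compound 2 (1.85 log units; beyond the scatter), concerns the group on the amide nitrogen.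

Compound 3 `O=C(CCc1cccc2c1B(O)OC2)Nc1cccc(-c2cccc(C(F)(F)F)c2)c1` differs from compound 2 by 3-(trifluoromethyl)phenyl in place of bromo on an aromatic carbon. Among the compounds with values here, no measured step touches this position, so the data give no direction here; a step of a 1.2-fold lower number from compound 2 to compound 3 (0.07 log units; within the scatter) is expected, within the scatter. Compound 3 is estimated at 1200 nM, between 250 nM and 6000 nM.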

Compound 3, half-maximal inhibitory concentration: 580 nM
The estimate for compound 3 lay 2.1-fold (0.32 log units) above the measured number; the range from low to high includes it.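

In this assay the swap of bromo for 3-(trifluoromethyl)phenyl gives a 2.4-fold lower number from compound 2 to compound 3 (0.38 log units; beyond the scatter) and so adds a first direction at this position: a modest gain, beyond the scatter. This carbon of the aromatic ring therefore accepts a much larger group, with a second aromatic ring, and activity is kept and slightly improved. Nothing shown here explains why this change has that effect.

As far as these compounds go, it remains open whether the trifluoromethyl on the new ring contributes, which a plain phenyl would test. From the compounds shown here alone, how an amine or a carboxylic acid at this position would behave is also open.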